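The source may report more compounds than this note shows. Statements on the series, on what has been measured and on what is new or still open speak of the compounds shown alone.

The measured compounds and their values:

compound 1, `FC(F)(F)c1cccc(NC(=S)Nc2cccc(Br)c2)c1` — 10000 nM
compound 2, `CCNC(=S)Nc1cccc(C(F)(F)F)c1` — > 100000 nM
compound 3, `O=[N+]([O-])c1ccc(NC(=S)Nc2cccc(C(F)(F)F)c2)cc1` — 10000 nM

The read-out here is an ADME assay on MDBK cells (Bos taurus) for cytotoxicity, read by MTT assay, with a stated time of 96 h; on this read-out higher numbers stand for lower toxicity in this test and lower numbers for higher toxicity in this test. In this assay compound 3 gives 10000 nM, which is level with compound 1 at 10000 nM; the two sit within the scatter of each other, so no order between them can be claimed. For compound 2 the value of > 100000 nM is a limit of the assay and not a number (the limit of > 100000 nM in this assay, at which 1 of the 3 values shown sits). Among the compounds with values here, the one step between measured compounds runs an at least 10-fold higher number from compound 1 to compound 2 (1.00 log units; beyond the scatter), with ethyl in place of 3-bromophenyl on an amide-type nitrogen.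

Compound 4, `Fc1ccc(NC(=S)Nc2cccc(C(F)(F)F)c2)cc1`, is not yet measured. It differs from compound 3 by fluoro in place of nitro on an aromatic carbon of a six-membered aromatic ring of carbon only, para to a large group. Within the data shown here, no measured step swaps one substituent on that ring for another; the single step known replaces the whole aryl group by ethyl, so it does not bear on this change. With compound 1 and compound 3 standing level despite their different rings, no change beyond the scatter is expected for the step of a 1.2-fold higher number from compound 3 to compound 4 (0.08 log units; within the scatter). Compound 4 is therefore estimated at 12000 nM, between 4000 nM and 40000 nM.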

Compound 4, half-maximal cytotoxic concentration: 41000 nM
Compound 4: middle estimate off by 3.4-fold (0.53 log units), on the low side; measured number outside the range, above it.
By their numbers in this assay, from the lowest: compounds 1 and 3 (each within the scatter of the next); then compound 4. At a limit, above all of these: compound 2.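

In this assay the substituent on this aromatic carbon, para to a large group, proves able to move the number: a 4.1-fold higher number from compound 3 to compound 4 (0.61 log units; beyond the scatter), with fluoro in place of nitro, whereas the earlier level pair of aryl compounds had shown no such spread. The two aryl groups on the amide-type nitrogen also no longer read alike, as a 4.1-fold higher number from compound 1 to compound 4 (0.61 log units; beyond the scatter), with 4-fluorophenyl in place of 3-bromophenyl, so a change of aryl group alone can now be seen to shift this read-out. Even so, 4-fluorophenyl does not reach the ethyl compound, since an at least 2.4-fold lower number from compound 2 to compound 4 (0.38 log units; beyond the scatter), and that step starts from compound 2, whose entry is a limit and not a number: the limit of > 100000 nM in this assay, at which 1 of the 4 values shown sits.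

What the compounds shown leave open is how other groups on this carbon, such as chloro, methoxy or an amine, would stand against fluoro and nitro, and where plain hydrogen would fall. The cause of the step stays open too, as no measured property of either group is given here.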